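This account rests on a few compounds, and the source may have more. Where it says the series, first, only, none or still open, it means among the compounds named here.

In a functional assay on A2780 cells (Homo sapiens) for antiproliferative activity, read by sulforhodamine B assay, with a stated time of 48 h (a higher number here means a weaker inhibitor of growth, a lower number a stronger inhibitor of growth), compound 1 `CC(C)(C)[Si](C)(C)O[C@H]1CCCO[C@@H]1CO` gives > 100000 nM, which is a limit of the assay and not a number. Compound 2 `CC(C)(C)[Si](C)(C)O[C@@H]1CCCO[C@@H]1COCC(=O)O` gives > 100000 nM, also a limit. Among the measured compounds shown here, compound 3 `CC(C)(C)[Si](C)(C)O[C@H]1CCCO[C@@H]1COCC(=O)OCc1ccccc1` gives 17000 nM, the only true number among the three. Compound 4 `CC(C)(C)[Si](C)(C)O[C@@H]1CCCO[C@@H]1COCC(=O)OCc1ccccc1` carries the same atoms and bonds as compound 3: the two compounds have the same atoms and bonds and differ only in configuration as drawn: 1 of 2 stereo elements differ; a stereocentre at a saturated ring carbon is drawn S in compound 3 and R in compound 4. For the measured compounds named here, the measured compounds include no step that changes only this stereocentre, so the expectation rests on compound 3 at 17000 nM, with no change beyond the scatter in either direction. The expected step of a 1.2-fold higher number from compound 3 to compound 4 (0.07 log units; within the scatter) is therefore small. Compound 4 is estimated at 20000 nM, with an expected range of 7000 nM to 60000 nM.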

Compound 4, concentration for 50% growth inhibition: 28000 nM
Compound 4: the middle estimate sits 1.4-fold (0.15 log units) below what was measured; low and high end bracket the measured number.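

In this assay, a 1.6-fold higher number from compound 3 to compound 4 (0.22 log units; within the scatter), and this step within the scatter can be tied only to this saturated ring stereocentre: the fact that compounds 3 and 4 differ only in the configuration as drawn

The benzyl in place of hydrogen on an oxygen next to a carbonyl group now has a readable step, an at least 3.5-fold lower number from compound 2 to compound 4 (0.55 log units; beyond the scatter). The value of compound 2, > 100000 nM, is a limit of the assay and not a number.

Still open, from the compounds shown here alone, is whether an amide or a longer chain in place of the benzyl group would move the number further. The role of the silyl group also stays open, since it is common to all the compounds shown.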